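This account rests on a few compounds, and the source may have more. Where it says the series, first, only, none or still open, it means among the compounds named here.

Measured in a functional assay on K562 cells (Homo sapiens) for cytotoxicity, read by MTT assay, with a stated time of 24 h; a higher number here means a weaker inhibitor, a lower number a stronger inhibitor:
- Compound 1 `COc1cc(/C=C2\CN(C)C/C(=C\c3ccccc3F)C2=O)cc(OC)c1OC`: 4340 nM
- Compound 2 `CN1C/C(=C\c2cccc([N+](=O)[O-])c2)C(=O)/C(=C/c2ccccc2F)C1`: 3890 nM
- Compound 3 `COc1cc(/C=C2\CN(C)C/C(=C\c3ccc(Cl)cc3Cl)C2=O)cc(OC)c1OC`: > 20000 nM (a limit, not a number)

Within the data shown here, compound 2, at 3890 nM, lies within the scatter of compound 1, and these two are the only exact numbers so far. Compound 4 `CN1C/C(=C\c2cccc([N+](=O)[O-])c2)C(=O)/C(=C/c2ccc(Cl)c(Cl)c2)C1` is compound 2 with one change: 3,4-dichlorophenyl in place of 2-fluorophenyl on a double-bonded chain carbon bound to a double-bonded ring carbon. It puts 3,4-dichlorophenyl in place of 2-fluorophenyl on a double-bonded chain carbon bound to a double-bonded ring carbon.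

Among the measured compounds shown here, one measured step bears on this change, and it also replaces 2-fluorophenyl with a dichlorophenyl group: an at least 4.6-fold higher number from compound 1 to compound 3 (0.66 log units; beyond the scatter). That step is only a lower bound. It involves 2,4-dichlorophenyl rather than 3,4-dichlorophenyl, and the rest of its structure differs from compound 2, so it carries over only in part. A rise in the number, meaning a weaker inhibitor in this assay, is therefore expected, though it may be smaller than that step. The expected change is a 2.3-fold higher number from compound 2 to compound 4 (0.36 log units; beyond the scatter). For compound 4 the estimated value is 9000 nM, with an expected range of 2500 nM to 25000 nM.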

Compound 4, half-maximal inhibitory concentration: 15500 nM
Compound 4: the middle estimate sits 1.7-fold (0.24 log units) below what was measured; the measured number falls inside the stated range.
By their numbers in this assay, from the lowest: compounds 2 and 1 (each within the scatter of the next); then compound 4. At a limit, above all of these: compound 3.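

In this assay, replacing 2-fluorophenyl with a dichlorophenyl group at this position now has an exact size, a 4.0-fold higher number from compound 2 to compound 4 (0.60 log units; beyond the scatter), whereas the earlier step gave only a bound, an at least 4.6-fold higher number from compound 1 to compound 3 (0.66 log units; beyond the scatter). The rise therefore appears with two different dichlorophenyl groups in two different compounds, and neither pair shown goes against it. Compound 3 gives only a limit, not a number: the limit of > 20000 nM in this assay, at which 1 of the 4 values shown sits.

The 2,4-dichlorophenyl and 3,4-dichlorophenyl groups stand on compounds that differ in more than one place, so the compounds shown do not separate the two chlorine patterns from each other. From the compounds shown here alone, it also stays open how a phenyl ring with a single chlorine, a methoxy group or an amine would read on this double-bonded chain carbon.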